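The source may report more compounds than this note shows. Statements on the series, on what has been measured and on what is new or still open speak of the compounds shown alone.

Measured in a functional assay on SiHa cells (Homo sapiens) for inhibition, read by sulforhodamine B assay; a lower number here means a stronger inhibitor of growth, a higher number a weaker inhibitor of growth:
Compound 1 `Fc1ccc(-c2ccc(-c3ccc(-c4nc5ccccc5[nH]4)cc3)cc2)cc1`: 29700 nM
Compound 2 `COc1ccc(-c2ccc(-c3ccc(-c4nc5ccccc5[nH]4)cc3)cc2)cc1`: 2760 nM
Compound 3 `CN(C)c1ccc(-c2ccc(-c3ccc(-c4nc5ccccc5[nH]4)cc3)cc2)cc1`: 100000 nM

Among these three, compound 3 has the highest number, at 100000 nM, and is the weakest inhibitor of growth. Compound 4 `COc1ccc(-c2ccc(-c3ccc(-c4nc5ccccc5[nH]4)cc3)cc2)cc1OC` is still unmeasured. It carries 3,4-dimethoxyphenyl in place of 4-(dimethylamino)phenyl, para to a large group: 3,4-dimethoxyphenyl in place of 4-(dimethylamino)phenyl on an aromatic carbon.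

The closest evidence is a 36-fold higher number from compound 2 to compound 3 (1.56 log units; beyond the scatter), a large step that runs opposite to this change. Methoxy also gave an 11-fold lower number from compound 1 to compound 2 (1.03 log units; beyond the scatter), whereas dimethylamino gave a 3.4-fold higher number from compound 1 to compound 3 (0.53 log units; beyond the scatter), a modest step. Among the compounds with values here, no measured compound shows what a second methoxy does. A large fall in this assay is therefore expected, an estimated 20-fold lower number from compound 3 to compound 4 (1.30 log units; beyond the scatter). Compound 4 is expected at 5000 nM, within an estimated range of 1200 nM to 25000 nM.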

Compound 4, concentration for 50% growth inhibition: 6200 nM
The estimate for compound 4 lay 1.2-fold (0.09 log units) below the measured number; measured number inside the range.
By their numbers in this assay, from the lowest: compound 2; then compound 4; then compound 1; then compound 3.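

In this assay, the move to 3,4-dimethoxyphenyl gives a 16-fold lower number from compound 3 to compound 4 (1.21 log units; beyond the scatter), so this position accepts a ring with two methoxy groups far better than 4-(dimethylamino)phenyl. The added methoxy itself is not a gain, since methoxy in place of hydrogen gives a 2.2-fold higher number from compound 2 to compound 4 (0.35 log units; beyond the scatter), a modest step. Against the fluoro compound, the change still gives a 4.8-fold lower number from compound 1 to compound 4 (0.68 log units; beyond the scatter), also modest.

No evidence is available to explain these steps. On these data alone, whether a hydroxy group or a longer chain such as ethoxy would be tolerated at this position remains open.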